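The compounds below may be only part of what the source reports. "The series", "measured", "known", "first", "only" and "open" are said of these compounds alone.

Measured compounds:
Compound 1, `CCCCC[Se]c1nc(NCc2ccc(SC)cc2)c2ccccc2n1`: 95300 nM
Compound 2, `CSc1nc(NCc2ccc([Se]C)cc2)c2ccccc2n1`: > 100000 nM
Compound 3, `CSc1nc(NCc2ccccc2)c2ccccc2n1`: > 100000 nM

The three measured compounds share one core and were all tested in a functional assay on MCF7 cells (Homo sapiens) for cytotoxicity, read by MTT assay, with a stated time of 72 h; on this read-out higher numbers stand for lower toxicity in this test and lower numbers for higher toxicity in this test. Compound 1 gives 95300 nM in this assay. For compound 2 the assay reports only a limit, > 100000 nM. For compound 3 the assay likewise reports only a limit, > 100000 nM. Compound 3 therefore stands at the edge of what this assay can read, and the limit of > 100000 nM in this assay, at which 2 of the 3 values shown sit, holds two of the three values shown.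

The unmeasured compound 4, `CSc1ccc(CNc2nc(SC)nc3ccccc23)cc1`, differs from compound 3 by methylsulfanyl in place of hydrogen on an aromatic carbon. The only single-point step measured among these compounds, a step that the two limits leave unreadable from compound 2 to compound 3, is the closest comparison, yet it does not tell the size of the step from compound 3 to compound 4: both of its ends are limits, so neither direction nor magnitude can be read from it. Compound 4 carries the same methylsulfanyl-bearing benzyl group as compound 1. In this assay compound 1 gives 95300 nM.

Given this, compound 4 is expected to move a number no higher from compound 3 to compound 4 (the limit leaves the size open), that is, to stay at or near the limit. Compound 4 is estimated at 100000 nM in this assay, with a range from 50000 nM to 300000 nM.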

Compound 4, concentration lethal to 50% of the cells: > 100000 nM
Compound 4 ended at the assay's limit; the forecaster's own chance of this, stated with the estimate: 65%; the middle value sits exactly at the limit.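

The value of compound 4 in this assay is a limit and not a number, so the steps that reach it from compound 2 and from compound 3 cannot be read. Even so, it shows that methylsulfanyl on this aromatic carbon, para to a large group, leaves the compound at the edge of what the assay can read, as hydrogen in compound 3 and the selenium-bearing group in compound 2 also do: the limit of > 100000 nM in this assay, at which 3 of the 4 values shown sit. The one step that can be read concerns a different place, the aromatic carbon that carries the pentyl chain on selenium in compound 1, and it is an at least 1.0-fold higher number from compound 1 to compound 4 (0.02 log units; that floor lies within the scatter), so this change of group gives no difference that can be told from the scatter.

As far as these compounds go, what an amine or a carboxylic acid para to a large group would give in this assay stays open. Also open, from the compounds shown here alone, is whether any group in that place would bring a value within the readable range, and so whether sulfur and selenium there differ at all.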